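A few compounds are considered here, and "the series" means these few. Any claim that something is new, unique, unknown or untested is made for them only; others in the source may bear on it.

Measured compounds:
compound 1, `Cc1ccc(N2CCN(Cn3nc(-c4ccc5c(c4)OCCO5)oc3=S)CC2)c(C)c1` — in a functional assay on BGC-823 cells (Homo sapiens) for antiproliferative activity, read by MTT assay, with a stated time of 48 h (on this read-out higher numbers stand for weaker inhibition and lower numbers for stronger inhibition), compound 1 gives 28300 nM
compound 2, `COc1cccc(N2CCN(Cn3nc(-c4ccc5c(c4)OCCO5)oc3=S)CC2)c1` — compound 2 reaches only a limit of the assay, > 50000 nM
compound 3, `S=c1oc(-c2ccc3c(c2)OCCO3)nn1CN1CCN(c2ccccn2)CC1` — compound 3 gives 25900 nM

All three share one core and differ only in the group on the amine nitrogen of the six-membered ring. Compound 3 and compound 1 sit within the scatter of each other: a 1.1-fold lower number from compound 1 to compound 3 (0.04 log units; within the scatter). The step of an at least 1.9-fold lower number from compound 2 to compound 3 (0.28 log units; that floor lies within the scatter) rests on a floor that also lies within the scatter, because of the limit of > 50000 nM in this assay, at which 1 of the 3 values shown sits. Compound 4, `O=[N+]([O-])c1ccc(N2CCN(Cn3nc(-c4ccc5c(c4)OCCO5)oc3=S)CC2)cc1`, carries the change (4-nitrophenyl in place of pyridin-2-yl on an amine nitrogen in a ring). The two measured steps on this position, an at least 1.7-fold higher number from compound 1 to compound 2 (0.24 log units; that floor lies within the scatter) and a 1.1-fold lower number from compound 1 to compound 3 (0.04 log units; within the scatter), show no swing beyond the scatter, so the exchange of aryl groups here has left the read-out close to where compound 3 stands. Compound 4 is therefore expected to stay near that level, with a step of a 1.2-fold higher number from compound 3 to compound 4 (0.06 log units; within the scatter) not clearly beyond the scatter, though a limit result cannot be excluded. The estimate for compound 4 in this assay is 30000 nM, with a range from 12000 nM to 80000 nM.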

Compound 4, half-maximal inhibitory concentration: > 50000 nM
Compound 4: no number, only a limit (the forecaster's own chance of this, stated with the estimate: 30%); middle value at least 1.6-fold (0.22 log units) away from the limit.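

With 4-nitrophenyl on the amine nitrogen, compound 4 gives no number in this assay, only a limit of the assay, so a second aryl group at this position, after the 3-methoxyphenyl of compound 2, ends there. The two readable steps, an at least 1.9-fold higher number from compound 3 to compound 4 (0.28 log units; that floor lies within the scatter) and an at least 1.7-fold higher number from compound 1 to compound 4 (0.24 log units; that floor lies within the scatter), therefore give only floors, and neither floor shows a change beyond the scatter. The step from compound 2 to compound 4 cannot be read, because both compounds stop at the same edge of the read-out: the limit of > 50000 nM in this assay, at which 2 of the 4 values shown sit.

The compounds shown leave open whether any group at this position moves the read-out beyond the scatter. They also leave open what a longer alkyl chain or an acetyl group on this amine nitrogen would give in place of an aryl group.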